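Methoxy to methyl on the shared core: an expectation

The source may report more compounds than this note shows. Statements on the series, on what has been measured and on what is new or still open speak of the compounds shown alone.

Compound 1 `Cc1ccc2nc(NC(=O)c3cn(-c4ccccc4)nc3-c3ccccc3)sc2c1` gives > 50000 nM in a functional assay on HT-29 cells (Homo sapiens) for cytotoxicity, read by MTT assay, with a stated time of 72 h; on this read-out lower numbers stand for stronger inhibition and higher numbers for weaker inhibition.
Compound 2 `Cc1ccc2nc(NC(=O)c3cn(-c4ccccc4)nc3-c3ccc(F)cc3)sc2c1` gives 22900 nM in this assay.
Compound 3 `COc1ccc(-c2nn(-c3ccccc3)cc2C(=O)Nc2nc3ccc(OC)cc3s2)cc1` gives > 50000 nM in this assay.

Of the compounds shown here, three sharing an amide-linked core have been tested in this assay. For compound 1 the value > 50000 nM is a limit of the assay, not a number. Within the data shown here, compound 2 is the only one with a measured number, 22900 nM. For compound 3 the value > 50000 nM is again a limit. So compound 3 stands at the edge of what the assay can report, together with compound 1, as summarised by the limit of > 50000 nM in this assay, at which 2 of the 3 values shown sit. Among the measured compounds shown here, the single measured step, an at least 2.1-fold lower number from compound 1 to compound 2 (0.33 log units; beyond the scatter), concerns the phenyl ring at the far end of the molecule and not the fused ring system.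

Compound 4 `COc1ccc(-c2nn(-c3ccccc3)cc2C(=O)Nc2nc3ccc(C)cc3s2)cc1` has not yet been measured. It differs from compound 3 in one place: methyl in place of methoxy on an aromatic carbon. For the measured compounds named here, no measured pair isolates this swap, and the one measured step lies on a different ring, so nothing here points to a change beyond the scatter in this assay. Compound 4 is therefore expected to sit near the limit as well, estimated at 50000 nM within 20000 nM to 120000 nM. That estimate corresponds to an expected step of a number no higher from compound 3 to compound 4 (the limit leaves the size open).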

Compound 4, half-maximal inhibitory concentration: 21500 nM
Estimate against measurement, compound 4: 2.3-fold (0.37 log units) above; low and high end bracket the measured number.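

Changing 6-methoxy-1,3-benzothiazol-2-yl to 6-methyl-1,3-benzothiazol-2-yl gives the first measured effect on the fused ring system of the shared core, so activity in this assay responds to this place as well as to the phenyl ring at the far end: an at least 2.3-fold lower number from compound 3 to compound 4 (0.36 log units; beyond the scatter). With methyl on the fused ring system, the far phenyl ring also gives a readable comparison: methoxy in place of hydrogen produces an at least 2.3-fold lower number from compound 1 to compound 4 (0.36 log units; beyond the scatter), while methoxy in place of fluoro produces a 1.1-fold lower number from compound 2 to compound 4 (0.03 log units; within the scatter), which leaves compound 2 and compound 4 indistinguishable in this assay. The full size of the step from methoxy to methyl remains unknown because compound 3 has a limit rather than a number: the limit of > 50000 nM in this assay, at which 2 of the 4 values shown sit.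

The compounds shown leave open how an ethyl group, a chlorine atom or an amine at this place on the fused ring system would compare with methyl and methoxy. They also leave open whether the swap from methoxy to methyl has a similar effect when the far phenyl ring carries fluoro or only hydrogen.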